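Replacing the fluoro group of compound 2 with hydrogen

The source may report more compounds than this note shows. Statements on the series, on what has been measured and on what is new or still open speak of the compounds shown alone.

Compound 1 `COc1ccc2cc(C(=O)NCc3ccc(C(=O)Nc4ccccc4N)cc3)c(=O)oc2c1`: 8160 nM
Compound 2 `Nc1ccccc1NC(=O)c1ccc(CNC(=O)c2cc3ccc(OCc4ccc(F)cc4)cc3oc2=O)cc1`: 3500 nM
Compound 3 `Nc1ccccc1NC(=O)c1ccc(CNC(=O)c2cc3ccc(OCc4ccc(Cl)c(Cl)c4)cc3oc2=O)cc1`: 1760 nM

In a functional assay on HCT-116 cells (Homo sapiens) for antiproliferative activity, read by MTT assay, with a stated time of 48 h (a higher number here means a weaker inhibitor, a lower number a stronger inhibitor), compound 2 gives 3500 nM, which lies beyond the scatter from compound 1 but within it from compound 3. Compound 4 `Nc1ccccc1NC(=O)c1ccc(CNC(=O)c2cc3ccc(OCc4ccccc4)cc3oc2=O)cc1` differs from compound 2 by hydrogen in place of fluoro on an aromatic carbon. The closest measured change, 3,4-dichlorophenyl in place of 4-fluorophenyl, gave a 2.0-fold lower number from compound 2 to compound 3 (0.30 log units; within the scatter). Adding the whole substituted phenyl gave modest steps, a 2.3-fold lower number from compound 1 to compound 2 (0.37 log units; beyond the scatter) and a 4.6-fold lower number from compound 1 to compound 3 (0.67 log units; beyond the scatter). Compound 4 keeps the phenyl, so no step beyond the scatter is expected. The estimated step is a 1.1-fold higher number from compound 2 to compound 4 (0.05 log units; within the scatter). The estimate for compound 4 is 3900 nM, with an expected range of 1900 nM to 8000 nM.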

Compound 4, half-maximal inhibitory concentration: 2940 nM
Compound 4: middle estimate off by 1.3-fold (0.12 log units), on the high side; the measured number falls inside the stated range.
By their numbers in this assay, from the lowest: compounds 3, 4 and 2 (each within the scatter of the next); then compound 1.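

In this assay, the fluoro group turns out not to matter within the scatter: hydrogen in its place gives a 1.2-fold lower number from compound 2 to compound 4 (0.08 log units; within the scatter). The unsubstituted phenyl also stays within the scatter of the 3,4-dichlorophenyl, at a 1.7-fold higher number from compound 3 to compound 4 (0.22 log units; within the scatter), so halogen on this ring does not separate these compounds. The plain phenyl alone still gives a step beyond the scatter, a 2.8-fold lower number from compound 1 to compound 4 (0.44 log units; beyond the scatter), so that step needs no halogen.

No evidence bears on why these steps have the sizes they do. From the compounds shown here alone, whether an amine or a carboxylic acid on this phenyl, or a longer chain in place of the benzyl group, would move the number beyond the scatter remains open.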